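From methyl to 4-methoxybenzyl on the amide-type nitrogen

The source may hold more compounds than are shown below. What is called first, only, known or untested is meant among the compounds shown, and "the series" means these compounds.

Compound 1 `COc1cc(/C=C2/C(=O)N(C)c3ccc(O)cc32)cc(OC)c1OC` gives 6300 nM
Compound 2 `COc1ccc2c(c1)/C(=C\c1cc(OC)c(OC)c(OC)c1)C(=O)N2C` gives 3700 nM
Compound 3 `COc1cc(/C=C2\C(=O)N(C)c3ccc(Cl)cc32)cc(OC)c1OC` gives 7400 nM

These values come from a functional assay on NSCLC cells (Homo sapiens) for cytotoxicity, with a stated time of 48 h (on this read-out higher numbers stand for weaker inhibition of growth and lower numbers for stronger inhibition of growth), and all lie within the scatter of each other, so compound 2 holds no separate place among the three. Compound 4 `COc1ccc(CN2C(=O)/C(=C/c3cc(OC)c(OC)c(OC)c3)c3cc(OC)ccc32)cc1` differs from compound 2 by 4-methoxyphenyl in place of hydrogen on a saturated chain carbon bound to an amide-type nitrogen in a ring and the same difference reads methyl to 4-methoxybenzyl. Among the measured compounds shown here, the only measured step is a 1.7-fold lower number from compound 1 to compound 2 (0.23 log units; within the scatter) and it concerns a methyl on an oxygen on an aromatic ring, not this place. For the measured compounds named here, no measured compound varies the group on the amide-type nitrogen, so support is thin, and no step beyond the scatter is expected. For compound 4 the expected step is a 1.5-fold lower number from compound 2 to compound 4 (0.17 log units; within the scatter) and it remains a tentative estimate. The expected value for compound 4 in this assay is 2500 nM with a range of 500 nM to 9000 nM by this estimate.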

Compound 4, concentration for 50% growth inhibition: 2300 nM
Beside the measured number, compound 4's estimate is 1.1-fold (0.04 log units) above it; measured number inside the range.
By their numbers in this assay, from the lowest: compounds 4, 2, 1 and 3 (each within the scatter of the next, the first and the last beyond it).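

In this assay, the change gives a 1.6-fold lower number from compound 2 to compound 4 (0.21 log units; within the scatter). Compound 2 and compound 4 are the only pair shown that varies the group on the amide-type nitrogen, and they show that 4-methoxyphenyl, with its 8 heavy atoms and aromatic ring, can enter on the saturated chain carbon there without a step beyond the scatter. Nothing available explains this result. As far as these compounds go, whether a plain benzyl, a longer chain, an amine or a carboxylic acid at this place would give a step beyond the scatter stays open.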